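Working notes on the step from benzyl to allyl

The source may hold more compounds than are shown below. What is called first, only, known or untested is meant among the compounds shown, and "the series" means these compounds.

Measured in a functional assay on HOS cells (Homo sapiens) for antiproliferative activity, read by sulforhodamine B assay (on this read-out lower numbers stand for stronger inhibition of growth and higher numbers for weaker inhibition of growth), so far:
Compound 1 `CCCCC[C@@H]1O[C@H](COCc2ccccc2)[C@@H](OCc2ccccc2)[C@H](OCc2ccccc2)C1=O` gives > 50000 nM as a limit of the assay
Compound 2 `O=C1[C@H](Cc2ccccc2)O[C@H](COCc2ccccc2)[C@@H](OCc2ccccc2)[C@@H]1OCc1ccccc1` gives > 50000 nM as a limit of the assay

Among the compounds with values here, compound 2 stands only at a limit, with > 50000 nM as its sole reading and no number behind it. Within the data shown here, the series so far offers the limit of > 50000 nM in this assay, at which 2 of the 2 values shown sit, and nothing else.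

The next compound is compound 3 `C=CC[C@@H]1O[C@H](COCc2ccccc2)[C@@H](OCc2ccccc2)[C@H](OCc2ccccc2)C1=O` and the change is vinyl in place of phenyl on a saturated chain carbon bound to a saturated ring carbon which in words is vinyl in place of phenyl on a saturated chain carbon bound to a saturated ring carbon. The same difference, cut one bond further out, reads benzyl to allyl.

Among the measured compounds shown here, the one measured step at this place is a step that the two limits leave unreadable from compound 1 to compound 2 and it offers no size to carry over. Because the limit of > 50000 nM in this assay, at which 2 of the 2 values shown sit, holds for compound 1 and compound 2 alike, no step beyond the scatter is expected in this assay and no direction can be named. The expected change is a number no higher from compound 2 to compound 3 (the limit leaves the size open) and it is to be read against a limit. Compound 3 is estimated at 50000 nM with an expected range from 20000 nM to 100000 nM and may well report only a limit.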

Compound 3, concentration for 50% growth inhibition: 7600 nM
Beside the measured number, compound 3's estimate is 6.6-fold (0.82 log units) above it; the whole stated range lies above it.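

In this assay this place on the shared core is no longer silent: with vinyl on a saturated chain carbon bound to a saturated ring carbon, the series gives an at least 6.5-fold lower number from compound 2 to compound 3 (0.81 log units; beyond the scatter) and also an at least 6.5-fold lower number from compound 1 to compound 3 (0.81 log units; beyond the scatter) as the second step to the same compound. Within the data shown here, the change therefore separates compound 3 from both a compound carrying phenyl and a compound carrying butyl at this place, so neither the aromatic ring nor the longer saturated chain is shared with the one compound that gives a number. The step between the two earlier compounds still cannot be read, and the series rests mostly on a limit: the limit of > 50000 nM in this assay, at which 2 of the 3 values shown sit.

It remains open whether the double bond or only the short chain goes with the lower number, as a propyl group at this place, the saturated counterpart of allyl, stands in no compound shown. From the compounds shown here alone, how far this place tolerates other ends is also open, for instance a terminal amine, a carboxylic acid or a longer alkenyl chain, and so is the part played by the carbonyl of the shared core, which a hydroxyl group in its stead would test.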